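Swapping the Benzothiazole Sulfide for a Dimethylpyrimidine

The compounds below may be only part of what the source reports. "The series", "measured", "known", "first", "only" and "open" are said of these compounds alone.

In a functional assay on BCG823 cells (Homo sapiens) for inhibition, read by MTT assay, with a stated time of 72 h (a higher number here means a weaker inhibitor, a lower number a stronger inhibitor), compound 1 `C/C(=N\NC(=O)CSc1nc2ccccc2s1)c1ccc(C)c([N+](=O)[O-])c1` gives 17.8 ug/mL and compound 3 `C/C(=N\NC(=O)c1ccc(CSc2nc3ccccc3s2)cc1)c1ccc([N+](=O)[O-])cc1` gives 31.3 ug/mL. Compound 2 `O=C(N/N=C/c1c[nH]c2ccccc12)c1ccc(CSc2nc3ccccc3s2)cc1` is known in this assay only as a limit, > 80 ug/mL. It thus stands at the limit of > 80 ug/mL in this assay, at which 1 of the 3 values shown sits, and no number fixes where it lies beyond that. Compound 4 `Cc1cc(C)nc(SCc2ccc(C(=O)N/N=C/c3c[nH]c4ccccc34)cc2)n1` differs from compound 2 by 4,6-dimethylpyrimidin-2-yl in place of 1,3-benzothiazol-2-yl on a sulfur, in words 4,6-dimethylpyrimidin-2-yl in place of 1,3-benzothiazol-2-yl on a sulfur. Among the measured compounds shown here, no measured pair carries this change, so the step of an at least 1.0-fold lower number from compound 2 to compound 4 (0.02 log units; that floor lies within the scatter) is expected to be small, without a direction beyond the scatter. Compound 4 is therefore estimated at 75 ug/mL, between 35 ug/mL and 160 ug/mL, and may well again be reported only as a limit.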

Compound 4, half-maximal inhibitory concentration: 35.5 ug/mL
For compound 4 the middle estimate is 2.1-fold (0.32 log units) above the measured one; the measured number falls inside the stated range.
By their numbers in this assay, from the lowest: compounds 1, 3 and 4 (each within the scatter of the next). At a limit, above all of these: compound 2.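

Among the compounds shown here, on a sulfur whose other neighbour is a saturated chain carbon, 4,6-dimethylpyrimidin-2-yl in place of 1,3-benzothiazol-2-yl gives the first step that can be read in this assay (an at least 2.2-fold lower number from compound 2 to compound 4 (0.35 log units; beyond the scatter)). Compound 2 is a limit (> 80 ug/mL), so that step is only a floor. It shows that this one change on the sulfur, with the rest of compound 2 kept, is enough to yield a measured number. From the compounds shown here alone, whether the same change acts alike on the cores of compound 1 and compound 3 stays open. So does how a group such as an amine or a carboxylic acid would read on that sulfur.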